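The compounds below may be only part of what the source reports. "The series", "measured", "known", "first", "only" and "open" are said of these compounds alone.

Compound 1 (`Cc1cccc(-c2nccc3nc(N)nn23)c1`) is the starting point here. Within the data shown here, in a functional assay (Homo sapiens) (on this read-out lower numbers stand for stronger inhibition and higher numbers for weaker inhibition), compound 1 gives 5500 nM as its reading, the lowest number of the three measured so far and so the strongest inhibition among them. In this assay compound 2 (`Nc1nc2ccnc(-c3ccncc3)n2n1`) gives 18000 nM and compound 3 (`CC(=O)Nc1nc2ccnc(-c3cccc(C(F)(F)F)c3)n2n1`) gives 20000 nM as its reading. Both numbers lie clearly above that of compound 1.

The compound still unmeasured, compound 4 (`CCOC(=O)c1cccc(-c2nccc3nc(N)nn23)c1`), keeps the core of compound 1 and carries ethoxycarbonyl in place of methyl on an aromatic carbon. Among the measured compounds shown here, no two measured compounds differ in one place only, so the data hold no direct measure of what such a swap does. Compound 2 and compound 3 each differ from compound 1 in more than one place, which makes them only a loose guide. For the measured compounds named here, with compound 1 at 5500 nM as the lowest number so far, a modest step toward a higher number, meaning weaker inhibition, is expected. The estimated size of that move is a 2.2-fold higher number from compound 1 to compound 4 (0.34 log units; beyond the scatter) and it remains a rough expectation. For compound 4 the estimated value is 12000 nM with an expected range from 4000 nM to 30000 nM on this reading.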

Compound 4, half-maximal inhibitory concentration: 11500 nM
For compound 4 the middle estimate is 1.0-fold (0.02 log units) above the measured one, within the range that was stated.
By their numbers in this assay, from the lowest: compound 1; then compounds 4, 2 and 3 (each within the scatter of the next).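

Among these compounds, the swap of methyl for ethoxycarbonyl gives the first direct reading of a single change in this assay, with a 2.1-fold higher number from compound 1 to compound 4 (0.32 log units; beyond the scatter) as a modest move toward weaker inhibition. It concerns an aromatic carbon of the six-membered aromatic ring of carbon only, meta to a large group, and shows that this place can take a group of 5 heavy atoms, with 2 hydrogen-bond acceptors, in place of a methyl of 1 heavy atom at a modest cost rather than a complete loss of inhibition. Nothing available here shows which feature of the incoming group accounts for the step, whether its length, its carbonyl or its ester oxygen.

The compounds shown leave open whether any group at this place would give a lower number than methyl, since a carboxylic acid, a primary amide, an amine or a plain ethyl chain do not appear among them. They also leave open whether ethoxycarbonyl would have a similar effect at another carbon of the same ring, or on a compound that differs from compound 1 elsewhere in the structure.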